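A few compounds are considered here, and "the series" means these few. Any claim that something is new, unique, unknown or untested is made for them only; others in the source may bear on it.

Measured compounds:
Compound 1 `O=C(Nc1ccc(Oc2ccnc3[nH]ccc23)cc1)c1ccc(-c2ccc(Cl)cc2)cn1` gives > 10000 nM in a functional assay on MCF7 cells (Homo sapiens) for cytotoxicity, read by MTT assay, with a stated time of 72 h (a lower number here means a stronger inhibitor, a higher number a weaker inhibitor), which is a limit of the assay and not a number.
Compound 2 `O=C(Nc1ccc(Oc2ccnc3[nH]ccc23)cc1)c1ccc(-c2ccc(F)cc2F)cn1` gives > 10000 nM in this assay, again a limit.
Compound 3 `Cc1ccc(-c2ccnc(C(=O)Nc3ccc(Oc4ccnc5[nH]ccc45)cc3)c2)cc1` gives > 10000 nM in this assay, also a limit.

Going by the values given here, compound 3 thus stands at the limit, with no number of its own; all three measured values sit at the limit of > 10000 nM in this assay, at which 3 of the 3 values shown sit, so no compound can be placed above or below another. Compound 4 `O=C(Nc1ccc(Oc2ccnc3[nH]ccc23)cc1)c1cc(-c2ccc(Cl)cc2)ccn1` is the unmeasured compound. Its change from compound 3 is chloro in place of methyl on an aromatic carbon. Among the compounds with values here, the only measured step, a step that the two limits leave unreadable from compound 1 to compound 2, swaps one halogen-bearing ring for another and is left unreadable by the two limits, so it gives no size to carry over. The change from compound 3 to compound 4 keeps the shared core and alters only one substituent, and all three measured compounds with related substituents sit at the limit. The expectation for compound 4 is therefore no step beyond the scatter, a step that the limit leaves unreadable from compound 3 to compound 4. Compound 4 is estimated at 15000 nM, in the range 5000 nM to 50000 nM, most likely reported as a limit again.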

Compound 4, half-maximal inhibitory concentration: > 10000 nM
Compound 4 ended at the assay's limit (the forecaster's own chance of this, stated with the estimate: 80%); the middle value does not contradict the limit.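

Compound 3 and compound 4 both stop at a limit of the assay and not at a number, so no step can be read between them: the limit of > 10000 nM in this assay, at which 4 of the 4 values shown sit. The compounds shown leave open how strongly any of them acts in this assay, and whether swapping methyl for chloro changes anything there.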